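The compounds below may be only part of what the source reports. "The series", "measured", "known", "first", "only" and "open" are said of these compounds alone.

Measured compounds and values in an in vitro functional assay on HEK285-7 cells for antagonist activity at prostaglandin D2 receptor 2 (Homo sapiens), read by BRET and beta-arrestin recruitment; a lower number here means a stronger inhibitor, a higher number a weaker inhibitor:

compound 1 `O=C(O)Cc1sc(NC(=O)c2ccccc2)nc1-c1ccc(Cl)cc1`: 870 nM
compound 2 `COc1ccc(C(c2ccccn2)c2nc(-c3ccc(Cl)cc3)c(CC(=O)O)s2)cc1`: 310 nM
compound 3 `N#Cc1cc(-c2nc(C(c3ccc(F)cc3)c3ccc(F)cc3)sc2CC(=O)O)ccc1F`: 520 nM

All three share a core carrying a carboxymethyl group next to an aryl-bearing ring carbon, and they differ in the groups on either side of that core. In this assay compound 3 gives the second highest of the three numbers; its nearest neighbour is compound 1 and its furthest is compound 2, and both of those gaps are within the usual scatter of repeated measurements, so the three compounds cannot be separated from each other on these data.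

Compound 4 `COc1cc(-c2nc(C(c3ccc(F)cc3)c3ccc(F)cc3)sc2CC(=O)O)ccn1` is not yet measured. It differs from compound 3 in one place: 2-methoxypyridin-4-yl in place of 3-cyano-4-fluorophenyl on an aromatic carbon. For the measured compounds named here, no step between two measured compounds isolates a change of this kind, so there is no direct precedent. The three measured values cover a narrow band despite rather different substituents at both ends of the core, which argues for a step from compound 3 to compound 4 in this assay of no more than the scatter, in either direction. The expected step is a 1.2-fold higher number from compound 3 to compound 4 (0.06 log units; within the scatter). Compound 4 is therefore estimated at 600 nM, with a range from 250 nM to 1500 nM.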

Compound 4, half-maximal inhibitory concentration: 380 nM
Estimate against measurement, compound 4: 1.6-fold (0.20 log units) above; measured number inside the range.
By their numbers in this assay, from the lowest: compounds 2, 4, 3 and 1 (each within the scatter of the next, the first and the last beyond it).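

In this assay, putting 2-methoxypyridin-4-yl in place of 3-cyano-4-fluorophenyl on the aromatic carbon next to the ring nitrogen gives a 1.4-fold lower number from compound 3 to compound 4 (0.14 log units; within the scatter) and so leaves the read-out within the scatter. For the compounds shown here, this is the first reading of this position with everything else held fixed, as the earlier compounds differ at both ends of the core: here a six-membered aromatic ring of carbon only, carrying a nitrile and a fluorine, gives way to a six-membered aromatic ring with 1 hetero atom, carrying a methoxy group, with no change that can be told from the scatter. No measurement beyond these potency values is available to explain this result.

Going by these compounds alone, the single pair does not separate the parts of the exchange, since the nitrile, the fluorine, the ring nitrogen and the methoxy group all change together. Still open, going by these compounds, is how this position responds to an amine or an ethoxy group in place of the methoxy group, or to an unsubstituted phenyl ring in place of the whole aryl group.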